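The source may hold more compounds than are shown below. What is called first, only, known or untested is meant among the compounds shown, and "the series" means these compounds.

In a functional assay on MCF7 cells (Homo sapiens) for antiproliferative activity, read by MTT assay, with a stated time of 48 h (a higher number here means a weaker inhibitor, a lower number a stronger inhibitor), compound 1 (`COc1ccc(C(=O)c2ccc3c(c2)C=CC(C)(C)O3)c(NC(=O)CO)c1`) gives 200 nM and compound 2 (`C=C(c1cc(OC)c(OC)c(OC)c1)c1ccc(OC)cc1NC(=O)CO`) gives 110 nM on the same read-out, two numbers that lie within the usual scatter of each other. Compound 2 therefore cannot be ranked apart from compound 1 on these data. Compound 3 (`C=C(c1cc(OC)c(OC)c(OC)c1)c1ccc(OC)cc1NC(=O)CNC`) keeps all of compound 2 except one group, with methylamino in place of hydroxy on a saturated chain carbon bound to a carbonyl carbon. For the measured compounds named here, no measured pair of compounds shows this kind of change, so the expectation rests on the structural change alone. A modest move toward a higher number, meaning a weaker inhibitor, is expected, and it may prove no larger than the scatter. The estimated change is a 1.8-fold higher number from compound 2 to compound 3 (0.26 log units; within the scatter) in this assay when the measurement is made. Compound 3 is expected to read about 200 nM with a likely range from 40 nM to 1000 nM in this test.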

Compound 3, half-maximal inhibitory concentration: 240 nM
Compound 3: middle estimate off by 1.2-fold (0.08 log units), on the low side; measured number inside the range.
By their numbers in this assay, from the lowest: compounds 2, 1 and 3 (each within the scatter of the next, the first and the last beyond it).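

Putting methylamino in place of hydroxy on a saturated chain carbon bound to a carbonyl carbon gives, in this assay, a 2.2-fold higher number from compound 2 to compound 3 (0.34 log units; beyond the scatter), a modest step but one that lies beyond the scatter. For the compounds shown here, this is the first single-place change, and it shows that the position responds to this swap even though the counts of hydrogen-bond donors and acceptors are the same in both groups, while compound 3 still reads 240 nM. No measurement shown here accounts for the step.

From the compounds shown here alone, whether an unsubstituted amine, a dimethylamino group or a methoxy group at this place would read closer to compound 2 or to compound 3 remains open. So does whether the same swap would give a similar step on the core of compound 1.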